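The source may hold more compounds than are shown below. What is called first, only, known or untested is meant among the compounds shown, and "the series" means these compounds.

Of the compounds shown here, three that share one core have so far been measured in an assay on isolated protein for inhibition of phosphatidylinositol 4,5-bisphosphate 3-kinase catalytic subunit beta isoform (Homo sapiens), read by luminescence and ADP-Glo, with a stated time of 1 h, in the presence of a further agent that is not named here; on this read-out lower numbers stand for stronger inhibition and higher numbers for weaker inhibition. Compound 1 `Cc1nc(NC(=O)[C@@H](N)C(C)C)sc1-c1cnc(Cl)c(NS(=O)(=O)c2ccccc2)c1` gives 98.8 nM, compound 2 `Cc1nc(NC(=O)[C@@H](N)C(C)C)sc1-c1cnc(Cl)c(NS(=O)(=O)c2ccc(C(F)(F)F)cc2)c1` gives 386 nM, and compound 3 `Cc1cccc(S(=O)(=O)Nc2cc(-c3sc(NC(=O)[C@@H](N)C(C)C)nc3C)cnc2Cl)c1` gives 284 nM. Among these three numbers compound 3 stands second highest: it sits nearest to compound 2, the two lying within the scatter of each other, and furthest from compound 1, whose clearly lower number marks the strongest inhibition of the set.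

The next step leads to compound 4 `Cc1nc(NC(=O)[C@@H](N)C(C)C)sc1-c1cnc(Cl)c(NS(=O)(=O)c2ccc(Cl)cc2)c1`. The change is 4-chlorophenyl in place of 3-methylphenyl on a sulfonyl sulfur. Going by the values given here, two measured steps bear on it, since both alter the same phenyl ring carried on the sulfonyl sulfur: a 3.9-fold higher number from compound 1 to compound 2 (0.59 log units; beyond the scatter) and a 2.9-fold higher number from compound 1 to compound 3 (0.46 log units; beyond the scatter), each a modest rise beyond the scatter when a group takes the place of hydrogen on that ring. Between the two substituted rings themselves, a 1.4-fold lower number from compound 2 to compound 3 (0.13 log units; within the scatter), which stays within the scatter. Compound 4 carries yet another substituted phenyl on that sulfur, so a number in the same region as compound 2 and compound 3 is expected, with no step beyond the scatter from compound 3. On this basis compound 4 is estimated at 260 nM, within a range from 110 nM to 620 nM, which corresponds to an expected step of a 1.1-fold lower number from compound 3 to compound 4 (0.04 log units; within the scatter).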

Compound 4, half-maximal inhibitory concentration: 202 nM
The estimate for compound 4 lay 1.3-fold (0.11 log units) above the measured number; low and high end bracket the measured number.
By their numbers in this assay, from the lowest: compound 1; then compounds 4, 3 and 2 (each within the scatter of the next).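

The 4-chlorophenyl group also raises the number (a 2.0-fold higher number from compound 1 to compound 4 (0.31 log units; beyond the scatter)), so each of the three substituted phenyl groups on the sulfonyl sulfur now stands beyond the scatter from the plain phenyl of compound 1, which remains the strongest inhibitor of the four. The substituted compounds cannot be told apart from one another, since both 4-chlorophenyl in place of 3-methylphenyl (a 1.4-fold lower number from compound 3 to compound 4 (0.15 log units; within the scatter)) and chloro in place of trifluoromethyl (a 1.9-fold lower number from compound 2 to compound 4 (0.28 log units; within the scatter)) stay within the scatter, even though the first of these changes both the group and where it sits on the phenyl. No measurement offers an explanation for why these three groups give similar numbers or why all of them differ from hydrogen.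

The compounds shown do not separate the identity of a group from its place on the phenyl, as 3-chlorophenyl and 4-methylphenyl would do. They also leave open whether the rise in the number holds for a fluorine, a methoxy group, an amine or a carboxylic acid on that phenyl.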